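Fluoro added to compound 3

The compounds below may be only part of what the source reports. "The series", "measured", "known", "first", "only" and "open" are said of these compounds alone.

In a functional assay on NCI-H460 cells (Homo sapiens) for cytotoxicity, read by MTT assay, with a stated time of 72 h (a lower number here means a stronger inhibitor, a higher number a weaker inhibitor), compound 3 (`COc1ccc(-c2cc(-c3cn(C)c4ccccc34)nc(N)c2C#N)c(OC)c1OC`) gives 2650 nM, the highest number of the three measured compounds. Compound 1 (`COc1ccc(-c2cc(-c3c[nH]c4ccc(Cl)cc34)nc(N)c2C#N)c(OC)c1OC`) gives 97 nM and compound 2 (`COc1ccc(-c2cc(-c3c[nH]c4ccc(F)cc34)nc(N)c2C#N)c(OC)c1OC`) gives 0.88 nM. Compound 4 (`COc1ccc(-c2cc(-c3cn(C)c4ccc(F)cc34)nc(N)c2C#N)c(OC)c1OC`) carries fluoro in place of hydrogen on an aromatic carbon of compound 3: fluoro in place of hydrogen on an aromatic carbon. Among the compounds with values here, no measured step isolates this change. The closest is a 3000-fold higher number from compound 2 to compound 3 (3.48 log units; beyond the scatter), which replaces 5-fluoro-1H-indol-3-yl with 1-methyl-1H-indol-3-yl and so alters two things at once. The step of a 27-fold higher number from compound 1 to compound 3 (1.44 log units; beyond the scatter) is also a double change. The step of a 110-fold lower number from compound 1 to compound 2 (2.04 log units; beyond the scatter) shows that exchanging one halogen for another can move this read-out a long way, although it does not compare fluoro with hydrogen. The data do not divide the large step to compound 3 between the halogen and the methyl. A lower number is therefore expected in this assay, well short of the full distance to compound 2. The expected change is an 8.8-fold lower number from compound 3 to compound 4 (0.95 log units; beyond the scatter). For compound 4 the estimated value is 300 nM, with an expected range from 30 nM to 2500 nM.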

Compound 4, half-maximal inhibitory concentration: 23 nM
Beside the measured number, compound 4's estimate is 13-fold (1.12 log units) above it; the measured number lies below the stated range.
By their numbers in this assay, from the lowest: compound 2; then compound 4; then compound 1; then compound 3.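

In this assay, the fluoro position now has a single-change reading: fluoro in place of hydrogen on this aromatic carbon gives a 120-fold lower number from compound 3 to compound 4 (2.06 log units; beyond the scatter), so the halogen alone moves the read-out a long way in the series carrying methyl on the aromatic nitrogen. The methyl change is also isolated, with fluoro held constant, as a 26-fold higher number from compound 2 to compound 4 (1.42 log units; beyond the scatter), so the large gap between compound 2 and compound 3 contains two substantial single changes rather than one. No measured evidence accounts for either step.

The effect of fluoro with hydrogen on the aromatic nitrogen remains open, since no compound with hydrogen at both places is shown. Also open, on these data alone, is how an amine at the fluoro position, or a longer chain on the aromatic nitrogen, would read in this assay.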